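Phenyl replaces the substituted aryl on the pyrazole carbon

The source may hold more compounds than are shown below. What is called first, only, known or untested is meant among the compounds shown, and "the series" means these compounds.

Measured compounds:
compound 1 `Cc1cc(-c2c(C)nn(-c3nc(-c4ccc(Cl)c(Cl)c4)c(SC(C)C)s3)c2C(=O)O)cc(C)n1`, 580 nM
compound 2 `COc1cc(C#N)cc(-c2c(C)nn(-c3nc(-c4ccc(Cl)c(Cl)c4)c(SC(C)C)s3)c2C(=O)O)c1`, 5200 nM

In a functional assay on BJAB cells (Homo sapiens) for antiproliferative activity, with a stated time of 4 days (a lower number here means that less compound is needed, a higher number that more compound is needed for the effect), compound 2 gives the higher of the two numbers, with compound 1 sitting below it by a 9.0-fold higher number from compound 1 to compound 2 (0.95 log units; beyond the scatter), a step beyond the scatter. Compound 3 `Cc1nn(-c2nc(-c3ccc(Cl)c(Cl)c3)c(SC(C)C)s2)c(C(=O)O)c1-c1ccccc1` differs from compound 2 by phenyl in place of 3-cyano-5-methoxyphenyl on an aromatic carbon. Going by the values given here, only one measured step touches this position, the one from compound 1 to compound 2, and it exchanged one substituted aromatic group for another rather than removing substituents altogether, so it bears on the change to compound 3 only loosely. Given that the two measured aryl groups lie so far apart in this assay, compound 3 is expected to land between them, a modest move downward from compound 2 of a 2.6-fold lower number from compound 2 to compound 3 (0.41 log units; beyond the scatter). Compound 3 is therefore estimated at 2000 nM, with a range from 500 nM to 8000 nM.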

Compound 3, half-maximal effective concentration: 3000 nM
The estimate for compound 3 lay 1.5-fold (0.18 log units) below the measured number; the range from low to high includes it.
By their numbers in this assay, from the lowest: compound 1; then compounds 3 and 2 (each within the scatter of the next).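

In this assay, cutting 3-cyano-5-methoxyphenyl back to plain phenyl gives a 1.7-fold lower number from compound 2 to compound 3 (0.24 log units; within the scatter), so at this position on the pyrazole-like ring the nitrile and methoxy substituents together make no difference that can be read. Replacing 2,6-dimethylpyridin-4-yl with phenyl gives a 5.2-fold higher number from compound 1 to compound 3 (0.71 log units; beyond the scatter), which leaves compound 1 alone at the low end, while the two carbon-only aryl groups cannot be told apart. No measurement shown accounts for this gap. The compounds shown leave open whether the lower number goes with the ring nitrogen or with the two methyl groups of 2,6-dimethylpyridin-4-yl. A plain pyridin-4-yl and a 3,5-dimethylphenyl at the same carbon would separate the two.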